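The source may hold more compounds than are shown below. What is called first, only, known or untested is meant among the compounds shown, and "the series" means these compounds.

Compound 1 `CCC(=O)c1ccc2c(c1)C(n1ccccc1=O)=CC(C)(C)O2` gives 6.63 in a functional assay (aorta) with Rattus norvegicus as the target; on this read-out higher numbers stand for higher potency (the scale is a negative logarithm) and lower numbers for lower potency.
Compound 2 `CC1(C)C=C(n2ccccc2=O)c2cc(C(=O)c3ccc([N+](=O)[O-])cc3)ccc2O1` gives 6.2 in this assay.

For the measured compounds named here, compound 2 stands lowest of the two numbers measured so far, and the single measured step, a number 0.43 log units lower from compound 1 to compound 2 (beyond the scatter), is what sets it below compound 1. Compound 3 `Cc1ccccc1C(=O)c1ccc2c(c1)C(n1ccccc1=O)=CC(C)(C)O2` differs from compound 2 by 2-methylphenyl in place of 4-nitrophenyl on a carbonyl carbon. Going by the values given here, no measured step exchanges one aromatic group on that carbonyl carbon for another; the only step in hand replaced ethyl with 4-nitrophenyl, and it bears on the present change only indirectly, showing that altering the group on this carbonyl carbon moves potency by a modest amount. On that slim basis the change is expected to give a small step in this assay, with no firm direction. Compound 3 is therefore estimated at 6.4, with a range from 5.9 to 6.9. The step this estimate implies, a number 0.20 log units higher from compound 2 to compound 3 (within the scatter), is expected to stay near the scatter.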

Compound 3, logarithm of the reciprocal of the active concentration, log(1/C): 6.83
The estimate for compound 3 lay 0.43 log units below the measured number; the measured number falls inside the stated range.
By their numbers in this assay, from the lowest: compound 2; then compounds 1 and 3 (each within the scatter of the next).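

Placing 2-methylphenyl instead of 4-nitrophenyl on the carbonyl carbon gives a number 0.63 log units higher from compound 2 to compound 3 (beyond the scatter) in this assay, so the identity of the aromatic group at this place matters, and not only the presence of one. Set against ethyl, 2-methylphenyl gives a number 0.20 log units higher from compound 1 to compound 3 (within the scatter) and stays level with it, which shows that the loss seen with 4-nitrophenyl does not extend to every aromatic group here. No measurement on these compounds offers an explanation for the gap between the two aromatic groups.

For the compounds shown here, with only two aromatic groups in hand, the contributions of the methyl and the nitro group cannot be separated. As far as these compounds go, how an unsubstituted phenyl, a longer chain such as butyl, or an amine on this carbonyl carbon would compare remains open.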